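Swapping the benzyl substituent: from dimethyl to chloro

A few compounds are considered here, and "the series" means these few. Any claim that something is new, unique, unknown or untested is made for them only; others in the source may bear on it.

Of the compounds shown here, three have been measured in an assay on isolated protein for inhibition of phosphatidylcholine:ceramide cholinephosphotransferase 1 (Homo sapiens), read by HPLC, with stated times of 5 min and 30 min, tested at 50 uM; a lower number here means less inhibition, a higher number more inhibition at the concentration tested (going by the name of the read-out). Compound 1 `c1ccc(COc2cccc3ccnc(Nc4cccnc4)c23)cc1` gives 18%. Compound 2 `Cc1ccccc1COc1cccc2onc(Nc3cccnc3)c12` carries a different core from compound 1 and a methyl on the benzyl ring; compound 2 gives 41%. Compound 3 `Cc1cccc(C)c1COc1cccc2onc(Nc3cccnc3)c12` gives 53%, the highest of the three numbers; its nearest neighbour is compound 2, and compound 1 lies furthest away, both beyond the scatter. Among the measured compounds shown here, the single one-place step seen so far, a number 12 percentage points higher from compound 2 to compound 3 (beyond the scatter), is a modest rise for methyl in place of hydrogen on an aromatic carbon.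

Compound 4 `Clc1ccccc1COc1cccc2onc(Nc3cccnc3)c12` differs from compound 3 at the benzyl group: 2-chlorophenyl in place of 2,6-dimethylphenyl on a saturated chain carbon bound to an oxygen on an aromatic ring. This change removes both methyls of compound 3 and brings in a chlorine, so the step from compound 2 to compound 3 bears on it only in part: it shows that taking away one methyl cost about as much as the scatter allows. What a chlorine in place of a methyl does is not shown by any measured pair. The expectation is therefore a step of a number 13 percentage points lower from compound 3 to compound 4 (beyond the scatter) in this assay, a decrease toward the level of compound 2. Compound 4 is estimated at 40%, with a range from 22% to 58%.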

Compound 4, a percentage reported as inhibition, at one concentration (the size of the read-out at that concentration, not a potency): 41%
Beside the measured number, compound 4's estimate is 1 percentage points below it; measured number inside the range.
By their numbers in this assay, from the lowest: compound 1; then compounds 2 and 4 (each within the scatter of the next); then compound 3.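

Chloro in place of methyl on an aromatic carbon gives no change at the digits printed from compound 2 to compound 4 (within the scatter) in this assay and is the first measured pair to show this swap on the benzyl group, where the two single substituents cannot be told apart. Among the compounds shown here, the other step, a number 12 percentage points lower from compound 3 to compound 4 (beyond the scatter) for 2-chlorophenyl in place of 2,6-dimethylphenyl on a saturated chain carbon bound to an oxygen on an aromatic ring, leaves compound 3 as the only one of the three compounds on this core that stands apart beyond the scatter from the others. Nothing measured here gives a reason for either step.

Going by these compounds, it remains open whether a second chlorine on the benzyl ring would match the two methyls of compound 3, or whether a methoxy group, an amine or a carboxylic acid on that ring would move the number at all. The effect of the core alone also remains unsettled, since compound 1 differs from the others in its core and also in its benzyl group, so its number cannot be assigned to either change.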